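Trimming the Ketone Side Chain in a Bis-ether Series

The compounds below may be only part of what the source reports. "The series", "measured", "known", "first", "only" and "open" are said of these compounds alone.

Measured compounds:
Compound 1, `COc1cc(C(=O)O)ccc1OCCCCOc1ccc(C(=O)CC(C)(C)C)c(O)c1C`, gives 98.6%.
Compound 2, `COc1ccc(C(=O)O)cc1OCCCCOc1ccc(C(=O)CC(C)C)c(O)c1C`, gives 89.7%.

The two measured compounds share one core and differ only in the alkyl group attached to the carbonyl and in where the carboxylic acid sits on the far ring. In an assay on HEK293 cells for positive allosteric modulation of metabotropic glutamate receptor 2 (Rattus norvegicus), read by thallium flux, with a stated time of 2.5 min (a lower number here means a smaller maximal response, a higher number a larger maximal response), compound 1 reaches 98.6%, the higher of the two numbers, while compound 2 reaches 89.7%; the gap between them lies within the usual scatter, so the two cannot be told apart on these data.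

Compound 3, `COc1cc(C(=O)O)ccc1OCCCCOc1ccc(C(=O)C(C)C)c(O)c1C`, has not been measured. It differs from compound 1 as follows: isopropyl in place of neopentyl on a carbonyl carbon. Going by the values given here, since no pair of measured compounds differs in this one place, no measured step guides the expectation, and the two numbers so far sit close to one another. The change is expected to cost a little, with the step of a number 10.6 percentage points lower from compound 1 to compound 3 (beyond the scatter) expected to be small and most likely within the scatter. Compound 3 is therefore estimated to reach 88%, in a range from 70% to 104%.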

Compound 3, largest response reached (reported as percent of maximum), in percent of the reference or control that the assay uses: 73.1%
Compound 3: middle estimate off by 14.9 percentage points, on the high side, and the stated range covers the measured number.
By their numbers in this assay, from the lowest: compound 3; then compounds 2 and 1 (each within the scatter of the next).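

Going by these compounds alone, putting isopropyl in place of neopentyl on a carbonyl carbon gives a number 25.5 percentage points lower from compound 1 to compound 3 (beyond the scatter) in this assay, the first step in this set that changes one place only. Compound 1 and compound 2 differ in two places at once, so they could not isolate the alkyl group; this pair shows that the maximal response depends on that group, and that with the rest of compound 1 held fixed, neopentyl cannot be exchanged for isopropyl without a measurable loss. Nothing here gives a measured reason for this loss, so the step stands as an observation only.

The compounds shown leave open how the response changes along a wider set of groups on this carbonyl carbon, such as ethyl, tert-butyl, cyclopropyl or a longer chain, and so whether it follows the carbon count or depends on the particular shape of the neopentyl group. They also leave open whether the same exchange would give a step of similar size with the carboxylic acid placed as in compound 2, or with a tetrazole in place of that acid.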